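Benzyl ether variation on the isoflavone-type series: step to compound 4

The source may hold more compounds than are shown below. What is called first, only, known or untested is meant among the compounds shown, and "the series" means these compounds.

Compound 1 `COc1cc(OC)c(-c2coc3cc(OCc4ccccc4)ccc3c2=O)cc1OC` gives 2330 nM in a functional assay on B16 cells (Mus musculus) for antiproliferative activity, read by MTT assay, with a stated time of 24 h; on this read-out higher numbers stand for weaker inhibition and lower numbers for stronger inhibition. Compound 2 `COc1cc(OC)c(-c2coc3cc(OCc4ccccc4F)ccc3c2=O)cc1OC` gives 1610 nM and compound 3 `COc1cc(OC)c(-c2coc3cc(OCc4ccc(C#N)cc4)ccc3c2=O)cc1OC` gives 7000 nM, the highest of the three numbers, so compound 3 is the weakest inhibitor here. The move to compound 4 `COc1cc(OC)c(-c2coc3cc(OCc4cccc(C(F)(F)F)c4)ccc3c2=O)cc1OC` is 3-(trifluoromethyl)phenyl in place of 4-cyanophenyl on a saturated chain carbon bound to an oxygen on an aromatic ring. Bearing on it are a 3.0-fold higher number from compound 1 to compound 3 (0.48 log units; beyond the scatter) and a 4.3-fold higher number from compound 2 to compound 3 (0.64 log units; beyond the scatter), both showing that the cyano group carried the only loss beyond the scatter. Compound 4 carries no such group and no acceptor on that ring, so the number is expected to fall back toward that of compound 1, with a 2.8-fold lower number from compound 3 to compound 4 (0.45 log units; beyond the scatter). Compound 4 is therefore estimated at 2500 nM in this assay, within 1000 nM to 7000 nM.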

Compound 4, half-maximal inhibitory concentration: > 10000 nM
Compound 4: no number, only a limit (the forecaster's own chance of this, stated with the estimate: 5%); middle value at least 4.0-fold (0.60 log units) away from the limit.
By their numbers in this assay, from the lowest: compounds 2 and 1 (each within the scatter of the next); then compound 3. At a limit, above all of these: compound 4.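

In this assay compound 4 gives > 10000 nM, a limit and not a number. Loss on this benzyl ether does not require a nitrile or a hydrogen-bond acceptor on the ring: an at least 4.2-fold higher number from compound 1 to compound 4 (0.63 log units; beyond the scatter) and an at least 6.2-fold higher number from compound 2 to compound 4 (0.79 log units; beyond the scatter) both lie beyond the scatter. The floor of an at least 1.4-fold higher number from compound 3 to compound 4 (0.15 log units; that floor lies within the scatter) lies within the scatter, so the size of that step stays unsettled.

As far as these compounds go, without a true number for compound 4, the full size of the trifluoromethyl loss remains open. Also open, from the compounds shown here alone, is how an amine or a carboxylic acid on that phenyl ring would read.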